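The source may hold more compounds than are shown below. What is called first, only, known or untested is meant among the compounds shown, and "the series" means these compounds.

In a functional assay on MDA-MB-231 cells (Homo sapiens) for inhibition, read by MTT assay, with a stated time of 48 h (a higher number here means a weaker inhibitor, a lower number a stronger inhibitor), compound 3 `Clc1ccc(-c2nc3ccccn3c2Sc2ccccc2)cc1` gives 24500 nM. That number cannot be told apart from those of its two measured relatives: compound 1 `C(=C/c1nc2ccccn2c1Sc1ccccc1)\c1ccccc1` gives 25300 nM and compound 2 `N#Cc1ccc(-c2nc3ccccn3c2Sc2ccccc2)cc1` gives 17800 nM. Compound 4 `c1ccc(Sc2c(-c3ccsc3)nc3ccccn23)cc1` keeps the shared core and differs from compound 3 by one change, (thiophen-3-yl in place of 4-chlorophenyl on an aromatic carbon), with thiophen-3-yl in place of 4-chlorophenyl. Within the data shown here, three measured steps concern this same aromatic carbon or its group: a 1.4-fold lower number from compound 1 to compound 2 (0.15 log units; within the scatter), a 1.0-fold lower number from compound 1 to compound 3 (0.01 log units; within the scatter) and a 1.4-fold higher number from compound 2 to compound 3 (0.14 log units; within the scatter). All three lie within the scatter, although none of them tests a thiophen-3-yl group. No step beyond the scatter is therefore expected in this assay. The expected step is a 1.1-fold lower number from compound 3 to compound 4 (0.05 log units; within the scatter). The estimate for compound 4 is 22000 nM, with an expected range of 11000 nM to 45000 nM.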

Compound 4, half-maximal inhibitory concentration: 62800 nM
Beside the measured number, compound 4's estimate is 2.9-fold (0.46 log units) below it; the measured number lies above the stated range.
By their numbers in this assay, from the lowest: compounds 2, 3 and 1 (each within the scatter of the next); then compound 4.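

Thiophen-3-yl is the first group on this aromatic carbon to separate from the others, with a 2.6-fold higher number from compound 3 to compound 4 (0.41 log units; beyond the scatter) and a 3.5-fold higher number from compound 2 to compound 4 (0.55 log units; beyond the scatter) and a 2.5-fold higher number from compound 1 to compound 4 (0.39 log units; beyond the scatter) in this assay. The position therefore does respond to its group, though these steps are modest and the three earlier groups remain within the scatter of one another. Nothing available explains why this five-membered ring gives a weaker inhibitor. The compounds shown leave open whether other five-membered aromatic rings behave in the same way. On these data alone, how a phenyl group carrying an amine or a carboxylic acid would read on this carbon also remains open.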